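Benzimidazole Amide Replaces Fluorophenyl Amide in Vero Toxicity

This account rests on a few compounds, and the source may have more. Where it says the series, first, only, none or still open, it means among the compounds named here.

The set contains three measured compounds and one awaiting measurement in an ADME assay on Vero cells (Chlorocebus sabaeus) for cytotoxicity; on this read-out lower numbers stand for higher toxicity in this test and higher numbers for lower toxicity in this test. For the measured compounds named here, compound 1 `O=C(NCCO)c1cccc2[nH]c(-c3ccccn3)nc12` gives 568 uM and compound 2 `O=C(NCCO)c1cccc2[nH]c(-c3cccnc3)nc12` gives 682 uM; the single step between them, a 1.2-fold higher number from compound 1 to compound 2 (0.08 log units; within the scatter), is small. Compound 3 `COc1ccc(-c2nc3c(C(=O)Nc4ccccc4F)cccc3[nH]2)cc1OC` gives 24.5 uM, the lowest number of the three, and its distance from compound 1 and from compound 2 is beyond the scatter in both cases, so compound 3 is the most toxic compound measured here.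

Compound 4 `COc1ccc(-c2nc3c(C(=O)Nc4nc5ccccc5[nH]4)cccc3[nH]2)cc1OC` is the next compound to be measured. It differs from compound 3 in one place: 1H-benzimidazol-2-yl in place of 2-fluorophenyl on an amide-type nitrogen. Going by the values given here, no measured step in this assay touches an amide substituent; the only step in the set, a 1.2-fold higher number from compound 1 to compound 2 (0.08 log units; within the scatter), concerns a pyridyl group at another position and lies within the scatter, so it offers no guidance on direction here. With nothing to support a move either way, compound 4 is expected to stay close to compound 3, with a step of a 1.2-fold higher number from compound 3 to compound 4 (0.09 log units; within the scatter) that need not exceed the scatter. The estimated value for compound 4 in this assay is 30 uM, within a range from 10 uM to 100 uM.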

Compound 4, half-maximal toxic concentration: 51.8 uM
For compound 4 the middle estimate is 1.7-fold (0.24 log units) below the measured one; measured number inside the range.
By their numbers in this assay, from the lowest: compound 3; then compound 4; then compounds 1 and 2 (each within the scatter of the next).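

In this assay, for the compounds shown here, the substituent on the amide-type nitrogen is the first place in this set where a single change carries the number beyond the scatter: a 2.1-fold higher number from compound 3 to compound 4 (0.33 log units; beyond the scatter), whereas a 1.2-fold higher number from compound 1 to compound 2 (0.08 log units; within the scatter) stayed within it. The read-out therefore responds to this position, though only modestly, and the change from 2-fluorophenyl to 1H-benzimidazol-2-yl goes toward lower toxicity in this test on this one pair. The swap removes the fluorine and a single carbon ring and brings in a fused ring pair with 2 nitrogen atoms, 1 hydrogen-bond donor and 1 hydrogen-bond acceptor, and nothing measured here accounts for the step.

The compounds shown leave open which part of that swap goes with the higher number; a plain phenyl, an imidazol-2-yl, or a benzimidazol-2-yl with a methyl on its ring nitrogen, each on the same amide-type nitrogen, would begin to separate these parts. Going by these compounds, whether the same swap moves the number in the same direction on a different core also remains open, as the step rests on a single pair of compounds.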